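A few compounds are considered here, and "the series" means these few. Any claim that something is new, unique, unknown or untested is made for them only; others in the source may bear on it.

In a functional assay on UO-31 cells (Homo sapiens) for inhibition, read by sulforhodamine B assay, with a stated time of 48 h, tested at 10 uM (a lower number here means less inhibition, a higher number more inhibition at the concentration tested (going by the name of the read-out)), three compounds have been measured:

Compound 1 `Brc1cn2ccnc2c(-c2ccc3ncn(C4CCCCC4)c3c2)n1` gives 37.6%.
Compound 2 `COc1ccc(-c2cn3ccnc3c(-c3ccc4ncn(C5CCCCC5)c4c3)n2)cc1` gives 61.5%.
Compound 3 `Fc1ccc(-c2cn3ccnc3c(-c3ccc4ncn(C5CCCCC5)c4c3)n2)cc1` gives 37.8%.

Compound 3 stands second highest of these three numbers, yet its gap to compound 1 lies within the scatter, so the two cannot be told apart. Compound 2 stands clearly apart: the step of a number 23.7 percentage points lower from compound 2 to compound 3 (beyond the scatter) is beyond the scatter, as is a number 23.9 percentage points higher from compound 1 to compound 2 (beyond the scatter), while a number 0.2 percentage points higher from compound 1 to compound 3 (within the scatter) is not.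

Compound 4 `c1cn2cc(-c3ccsc3)nc(-c3ccc4ncn(C5CCCCC5)c4c3)c2n1` is not yet measured. It differs from compound 3 in one place: thiophen-3-yl in place of 4-fluorophenyl on an aromatic carbon. Among the compounds with values here, the measured steps all change the group at this same position, and they show that a change there can move the number modestly or not at all; none of them swaps a six-membered ring for a five-membered one, so no step speaks directly to this change. Compound 4 is therefore expected to stay near compound 3, with the step of a number 2.2 percentage points higher from compound 3 to compound 4 (within the scatter) estimated to lie within the scatter. The estimate for compound 4 is 40%, within 22% to 58%.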

Compound 4, a percentage reported as inhibition, at one concentration (the size of the read-out at that concentration, not a potency): 23.1%
For compound 4 the middle estimate is 16.9 percentage points above the measured one; low and high end bracket the measured number.
By their numbers in this assay, from the lowest: compound 4; then compounds 1 and 3 (each within the scatter of the next); then compound 2.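

Within the data shown here, measured against the bromo group of compound 1, the earlier aryl groups in this assay either raised the number or left it unchanged, whereas thiophen-3-yl is the first group here to lower it: a number 14.5 percentage points lower from compound 1 to compound 4 (beyond the scatter). Swapping a six-membered aromatic ring for a five-membered one holding sulfur is therefore not a neutral change, giving a number 14.7 percentage points lower from compound 3 to compound 4 (beyond the scatter), and the gap to the 4-methoxyphenyl group, a number 38.4 percentage points lower from compound 2 to compound 4 (beyond the scatter), is the largest step yet seen at this position. Nothing available here bears on why the number falls.

The compounds shown leave open whether ring size or the sulfur atom matters more; compound 4 changes both at once. They also leave open how an amine or a carboxylic acid on this aromatic carbon would compare with the 4-methoxyphenyl group of compound 2.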